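The source may report more compounds than this note shows. Statements on the series, on what has been measured and on what is new or still open speak of the compounds shown alone.

Compound 3 `CCCCCCCCCCn1cc(/C=C/C(=O)c2ccc(N)cc2)nn1` gives in a functional assay on SK-N-SH cells (Homo sapiens) for inhibition, read by MTT assay (a lower number here means a stronger inhibitor, a higher number a weaker inhibitor), a value of 83400 nM. Compound 1 `CCCCCCCCCCn1cc(/C=C/C(=O)c2ccc(NC(=O)CBr)cc2)nn1` carries the change ((bromomethyl)carbonyl in place of hydrogen on a nitrogen on an aromatic ring), and in this assay compound 1 gives 8680 nM, so that a 9.6-fold lower number from compound 3 to compound 1 (0.98 log units; beyond the scatter). Compound 2 `Nc1ccc(C(=O)/C=C/c2cn(Cc3ccc(Br)cc3)nn2)cc1` has a different core; how the two cores differ is not broken down here. In this assay compound 2 gives 25200 nM. Compound 4 `O=C(CBr)Nc1ccc(C(=O)/C=C/c2cn(Cc3ccc(Br)cc3)nn2)cc1` is the not yet measured compound; it is made from compound 2 by (bromomethyl)carbonyl in place of hydrogen on a nitrogen on an aromatic ring, the same kind of change that led from compound 3 to compound 1, at a place described in the same words. Because the earlier change gave a 9.6-fold lower number from compound 3 to compound 1 (0.98 log units; beyond the scatter), a step of about a 7.9-fold lower number from compound 2 to compound 4 (0.90 log units; beyond the scatter) is expected here as well. Compound 4 is therefore estimated at 3200 nM, with a likely range from 1100 nM to 10000 nM.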

Compound 4, half-maximal inhibitory concentration: 8300 nM
Beside the measured number, compound 4's estimate is 2.6-fold (0.41 log units) below it, within the range that was stated.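

In this assay, putting (bromomethyl)carbonyl on the amino nitrogen lowers the number on both cores, here with a 3.0-fold lower number from compound 2 to compound 4 (0.48 log units; beyond the scatter), but the size of the step does not carry over unchanged: the same change on two cores in this assay, a 9.6-fold lower number (0.98 log units; beyond the scatter) from compound 3 to compound 1 and a 3.0-fold lower number (0.48 log units; beyond the scatter) from compound 2 to compound 4, 3.2-fold (0.50 log units) apart, beyond the scatter of two such steps With that group present, 4-bromophenyl in place of nonyl gives a 1.0-fold lower number from compound 1 to compound 4 (0.02 log units; within the scatter). Two pairs show the same direction on these two cores, but they do not explain why the sizes differ or show how the change would behave on any other core.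

The compounds shown leave open whether a plain acetyl group or a chloroacetyl group on the same nitrogen would give a similar step. They also leave open how a shorter chain in place of nonyl would affect it.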